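The compounds below may be only part of what the source reports. "The series", "measured", "known", "first", "only" and "open" are said of these compounds alone.

Compound 1 `CC(C)(C)c1cc(NC(=O)Nc2cc(F)cc(F)c2)n(-c2ccccc2)n1`, compound 2 `Cn1nc(C(C)(C)C)cc1NC(=O)Nc1cc(F)cc(F)c1` and compound 3 `CC(C)(C)c1cc(NC(=O)Nc2cc(F)cc(F)c2)n(-c2ccc(F)cc2)n1` share one core and differ only in the group carried on an aromatic nitrogen of the five-membered ring. In an assay on isolated protein for inhibition of STE20-like serine/threonine-protein kinase (Homo sapiens), read by thermal shift assay, tested at 10 uM (a higher number here means that the compound stabilises the target more against heat, a lower number that the compound stabilises the target less), compound 1 gives 3 degrees C, compound 2 gives 1.2 degrees C and compound 3 gives 2.7 degrees C. Compound 3 therefore sits close to compound 1, the gap between them being small (a number 0.30 degrees C lower from compound 1 to compound 3 (within the scatter)), while its distance from compound 2 is a real one (a number 1.5 degrees C higher from compound 2 to compound 3 (beyond the scatter)). Compound 4 `CC(C)(C)c1cc(NC(=O)Nc2cc(F)cc(F)c2)n(C(C)(C)C)n1` has not yet been measured; it differs from compound 3 by tert-butyl in place of 4-fluorophenyl on an aromatic nitrogen. Going by the values given here, two measured steps concern the same position: a number 1.8 degrees C lower from compound 1 to compound 2 (beyond the scatter) and a number 1.5 degrees C higher from compound 2 to compound 3 (beyond the scatter). Both show that what sits on this nitrogen changes the outcome, and in both the methyl group gave the lower number. A tert-butyl group is neither a methyl nor a ring, so a step between those two cases, downward from compound 3, seems the most reasonable expectation. Compound 4 is expected to give 1.8 degrees C in this assay, with a likely range from 0.8 degrees C to 2.8 degrees C. That estimate corresponds to an expected step of a number 0.90 degrees C lower from compound 3 to compound 4 (within the scatter).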

Compound 4, shift of the target's melting temperature: 0.2 degrees C
Compound 4: middle estimate off by 1.6 degrees C, on the high side; measured number below the stated range.
By their numbers in this assay, from the lowest: compounds 4 and 2 (each within the scatter of the next); then compounds 3 and 1 (each within the scatter of the next).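

The step of a number 2.5 degrees C lower from compound 3 to compound 4 (beyond the scatter) and the step of a number 2.8 degrees C lower from compound 1 to compound 4 (beyond the scatter) show that a tert-butyl group on this aromatic nitrogen does not hold the level of the compounds that carry a ring there. The step of a number 1.0 degrees C lower from compound 2 to compound 4 (within the scatter) places it level with the methyl group, so tert-butyl and methyl cannot be told apart in this assay at this position. Across these four compounds the numbers split into two pairs: phenyl and 4-fluorophenyl give the higher pair, the two groups without a ring give the lower pair, and no compound goes against this.

From the compounds shown here alone, whether the ring must be aromatic stays open, and a cyclohexyl group or a pyridyl group on this nitrogen would bear on that. No measurement offered here explains the split.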